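Swapping the Aryl Group on a Shared Core

This account rests on a few compounds, and the source may have more. Where it says the series, first, only, none or still open, it means among the compounds named here.

Three compounds built on one shared core were tested in a functional assay on HCT-116 cells (Homo sapiens) for antiproliferative activity, read by MTT assay, with a stated time of 24 h; on this read-out lower numbers stand for stronger inhibition and higher numbers for weaker inhibition. Compound 1 `COc1ccc(C(=O)/C=C/c2ccc(-c3ccccc3)cc2)c2c1C=CC(C)(C)O2` stopped at the limit of the assay, giving > 10000 nM. Compound 2 `COc1ccc(C(=O)/C=C/c2cccc([N+](=O)[O-])c2)c2c1C=CC(C)(C)O2` gave a number, 8050 nM. Compound 3 `COc1ccc(/C=C/C(=O)c2ccc(OC)c3c2OC(C)(C)C=C3)cn1` also stopped at the limit, giving > 10000 nM. Compound 3 thus stands with a limit rather than a measured number, and it is not alone in that, because of the limit of > 10000 nM in this assay, at which 2 of the 3 values shown sit. Among the measured compounds shown here, the only change measured in one place is an at least 1.2-fold higher number from compound 2 to compound 3 (0.09 log units; that floor lies within the scatter), and its floor lies within the scatter of repeated measurements, so it shows no clear movement.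

Compound 4 `COc1ccc(C(=O)/C=C/c2ccc(O)c(Br)c2)c2c1C=CC(C)(C)O2` differs from compound 3 in a single place: 3-bromo-4-hydroxyphenyl in place of 6-methoxypyridin-3-yl on a double-bonded chain carbon bound to a double-bonded chain carbon. For the measured compounds named here, no measured step involves the group that enters, so the one measured step bears on this change only loosely, and it was itself small. The step is therefore expected to stay within the scatter: an at least 1.1-fold lower number from compound 3 to compound 4 (0.04 log units; that floor lies within the scatter). Compound 4 is estimated at 9000 nM, with a range from 3000 nM to 30000 nM, and a real chance that only a limit is reported.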

Compound 4, half-maximal inhibitory concentration: > 10000 nM
Compound 4: a limit, no number (the forecaster's own chance of this, stated with the estimate: 50%); middle value at least 1.1-fold (0.04 log units) from the limit.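

Among the compounds shown here, with 3-bromo-4-hydroxyphenyl on the double-bonded chain carbon, the first group here to bring a hydrogen-bond donor, compound 4 also ends at a limit rather than a number: the limit of > 10000 nM in this assay, at which 3 of the 4 values shown sit. For the compounds shown here, compound 3 and compound 4 both sit at that limit, so the step between them cannot be read, and the only readable step is an at least 1.2-fold higher number from compound 2 to compound 4 (0.09 log units; that floor lies within the scatter), which shows no clear movement. Three further aryl groups at this place, including the one with the donor, have therefore given no number clearly separated from that of compound 2.

On these data alone, how far compound 1, compound 3 and compound 4 lie from one another remains unknown, since only limits are available for them. Also open, as far as these compounds go, is whether a phenyl ring carrying an amine or a carboxylic acid at this place would give a clearly lower number.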